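Swapping the aryl group on a fused sulfonamide core

The compounds below may be only part of what the source reports. "The series", "measured", "known", "first", "only" and "open" are said of these compounds alone.

Measured compounds:
compound 1 `COc1ccc(S(=O)(=O)N2CCc3cccc(-c4ccc(F)nc4)c32)cc1`: 109 nM
compound 2 `COc1ccc(S(=O)(=O)N2CCc3cccc(-c4c(F)c(F)c(F)c(F)c4F)c32)cc1`: 3900 nM

In a functional assay on HT-29 cells (Homo sapiens) for inhibition, with a stated time of 72 h (a higher number here means a weaker inhibitor, a lower number a stronger inhibitor), compound 1 gives 109 nM, the lowest of the two numbers, while compound 2 gives 3900 nM, a gap beyond the usual scatter. Compound 3 `COc1ccc(S(=O)(=O)N2CCc3cccc(-c4cccs4)c32)cc1` has not yet been measured. It differs from compound 1 by thiophen-2-yl in place of 6-fluoropyridin-3-yl on an aromatic carbon. Going by the values given here, with no measured step of this kind to lean on, a small step is expected, somewhat toward a higher number: a 1.8-fold higher number from compound 1 to compound 3 (0.26 log units; within the scatter). For compound 3 the estimate in this assay is 200 nM, with a range from 60 nM to 800 nM.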

Compound 3, half-maximal inhibitory concentration: 200 nM
For compound 3 middle estimate and measured number coincide at the digits printed, and the stated range covers the measured number.
By their numbers in this assay, from the lowest: compounds 1 and 3 (each within the scatter of the next); then compound 2.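

In this assay, the step of a 1.8-fold higher number from compound 1 to compound 3 (0.26 log units; within the scatter) shows that this aromatic carbon accepts a five-membered aromatic ring with sulfur as readily as the six-membered ring of compound 1, so neither that ring size nor its nitrogen and fluorine is needed here. Compound 3, at 200 nM, also shows that the much higher number of compound 2, at 3900 nM, is not shared by every change of aromatic ring at this carbon. Nothing measured here explains these numbers.

As far as these compounds go, it remains open whether an amine, a carboxylic acid or a longer chain on this carbon would keep the number in this range. From the compounds shown here alone, whether a thiophen-3-yl group would read like thiophen-2-yl also remains open.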